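The source may hold more compounds than are shown below. What is called first, only, known or untested is meant among the compounds shown, and "the series" means these compounds.

Of the compounds shown here, three have so far been tested in an ADME assay on HepG2 cells (Homo sapiens) for cytotoxicity, in the presence of a further agent that is not named here; a lower number here means a stronger inhibitor, a higher number a weaker inhibitor. Compound 1 has the structure `COc1nc(C(C)c2ccccc2C(F)(F)F)nc(C(=O)NCc2ccccc2)c1O` and reaches only a limit of the assay, namely > 100000 nM. Compound 2 is built as `CN(Cc1ccccc1)C(=O)c1nc(Cc2ccccc2C(F)(F)F)n(C)c(=O)c1O` and likewise gives only a limit in this assay, which is > 100000 nM. Compound 3 is drawn as `COc1c(C(=O)NCc2ccccc2)nc(Cc2ccccc2C(F)(F)F)n(C)c1=O` and also stops at a limit in this assay, at > 100000 nM. Compound 2 therefore stands nowhere that can be ranked: its own value is a limit, and the other two values shown are limits as well, as summed up in the limit of > 100000 nM in this assay, at which 3 of the 3 values shown sit. Compound 4 has the structure `Cn1c(Cc2ccccc2C(F)(F)F)nc(C(=O)NCC2CCCCC2)c(O)c1=O` and has not yet been measured in this assay. It differs from compound 2 in one place: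

(cyclohexylmethyl)amino in place of benzyl(methyl)amino on a carbonyl carbon

Because every measured value sits at the limit of > 100000 nM in this assay, at which 3 of the 3 values shown sit, the expected change a step that the limit leaves unreadable from compound 2 to compound 4 is none beyond the usual scatter. Compound 4 is thus estimated at 150000 nM in this assay, within a range from 50000 nM to 500000 nM, and will most likely again be reported only as a limit.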

Compound 4, half-maximal inhibitory concentration: > 100000 nM
Compound 4: only a limit was reported; the forecaster's own chance of this, stated with the estimate: 85%; the middle value lies beyond the limit too.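

Among these compounds, compound 2 and compound 4 both stop at a limit in this assay, so no step between them can be read: the limit of > 100000 nM in this assay, at which 4 of the 4 values shown sit.

The compounds shown leave open how strongly any of them acts in this assay and whether exchanging benzyl(methyl)amino for (cyclohexylmethyl)amino changes anything there.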